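Removing a Hydroxymethyl Group from Compound 1

A few compounds are considered here, and "the series" means these few. Any claim that something is new, unique, unknown or untested is made for them only; others in the source may bear on it.

Measured compounds:
compound 1, `C=CCc1cc(O)c(O)c(CN2CCC(CCO)CC2)c1`, 40.6%
compound 2, `C=CCc1ccc(OCc2cn(-c3ccc(Br)cc3)nn2)c(O)c1`, 61.7%

Both measured compounds were tested in a functional assay on SK-N-SH cells (Homo sapiens) for inhibition, read by MTT assay, with a stated time of 72 h, tested at 50 uM; a higher number here means more inhibition of growth at the concentration tested, a lower number less inhibition of growth. Compound 1 gives 40.6%, the lowest of the two numbers. Compound 2 gives 61.7%, a number that lies beyond the usual scatter above compound 1. The two structures differ in several places at once, so the gap between them cannot be tied to any single change.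

Compound 3, `C=CCc1cc(O)c(O)c(CN2CCC(C)CC2)c1`, has not yet been measured. It differs from compound 1 in one place: hydrogen in place of hydroxymethyl on a saturated chain carbon bound to a saturated ring carbon. Going by the values given here, no pair of measured compounds isolates a change of this kind, so the data give no direct size for it. A small group leaves and only a hydrogen takes its place, which gives reason to expect at most a modest step in this assay, in either direction, and quite possibly none beyond the scatter.

Compound 3 is therefore estimated at 42%, within a range of 26% to 58%. The step of a number 1.4 percentage points higher from compound 1 to compound 3 (within the scatter) is expected to be small.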

Compound 3, percent growth inhibition at one concentration: 84.2%
The estimate for compound 3 lay 42.2 percentage points below the measured number; measured number outside the range, above it.
By their numbers in this assay, from the lowest: compound 1; then compound 2; then compound 3.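

In this assay, this place on the core of compound 1 proves highly sensitive: the step of a number 43.6 percentage points higher from compound 1 to compound 3 (beyond the scatter) comes from hydrogen in place of hydroxymethyl on a saturated chain carbon bound to a saturated ring carbon, a change that removes only 2 heavy atoms. Going by these compounds alone, until now no pair of compounds isolated a single change, so this is the first size available for one, and it shows that a small edit here, which can equally be read as 2-hydroxyethyl giving way to methyl, can move growth inhibition far beyond the usual scatter. Nothing at hand explains the size of this step.

The compounds shown do not separate the loss of the oxygen from the shortening of the chain, since an ethyl group at this place would keep the chain length of 2-hydroxyethyl without its oxygen. They also leave open whether a longer chain such as propyl, or an amine in place of the hydroxyl, would behave like the methyl of compound 3 or like the 2-hydroxyethyl of compound 1.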